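The compounds below may be only part of what the source reports. "The series", "measured", "known", "first", "only" and "open" are said of these compounds alone.

Compound 1, `O=C1c2c[n+]([O-])c3ccccc3c2C(=O)c2c1c1ccccc1n2Cc1cn(CC(O)CO)nn1`: in a functional assay on SH-SY5Y cells (Homo sapiens) for cytotoxicity, read by MTT assay, with a stated time of 72 h (on this read-out lower numbers stand for stronger inhibition and higher numbers for weaker inhibition), compound 1 gives > 1000 nM, which is a limit of the assay and not a number.
Compound 2, `CC1(C)OC[C@@H](Cn2cc(Cn3c4c(c5ccccc53)C(=O)c3c[n+]([O-])c5ccccc5c3C4=O)nn2)O1`: compound 2 gives > 1000 nM, again only a limit of the assay.
Compound 3, `O=C1c2c[n+]([O-])c3ccccc3c2C(=O)c2c1c1ccccc1n2CCN1CCCCC1`: compound 3 gives 1860 nM.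

Compound 1 therefore stands at the edge of what this assay reports, and it shares that position with one other compound: the limit of > 1000 nM in this assay, at which 2 of the 3 values shown sit. Two measured steps start from compound 1, and neither can be read. The change of a step that the two limits leave unreadable from compound 1 to compound 2 is hidden by two limits, and the change of a step that the limit leaves unreadable from compound 1 to compound 3 is hidden by one limit, so no size and no direction can be taken from either.

Compound 4, `O=C1c2c[n+]([O-])c3ccccc3c2C(=O)c2c1c1ccccc1n2Cc1cn(C[C@@H](O)CO)nn1`, differs from compound 1 only in stereochemistry: the two compounds have the same atoms and bonds; at least one stereo element is drawn with a configuration in one of them and without one in the other: 1 of 1 stereo elements differ; a stereocentre at a saturated chain carbon is drawn without a configuration in compound 1 and R in compound 4. Among the compounds with values here, none of the measured steps concerns a stereocentre being drawn with or without a configuration, so no step bears directly on this change. With compound 1 at a limit and the shared core unchanged, compound 4 is expected to stay at or beyond that same limit, which amounts to an expected step that the limit leaves unreadable from compound 1 to compound 4 in this assay. The estimate for compound 4 is 3000 nM, with a range from 1000 nM to 10000 nM.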

Compound 4, half-maximal inhibitory concentration: > 500 nM
Compound 4: a limit, no number; the forecaster's own chance of this, stated with the estimate: 85%; the middle value is on the limit's open side.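

No new step can be read: every step that reaches compound 4 from compound 1, compound 2 or compound 3 involves at least one limit of the assay, and none shows a size or a direction. The compounds shown leave open whether the R configuration drawn in compound 4 changes the read-out at all.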